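Oral exposure in the acyl-urea series: the next step

The compounds below may be only part of what the source reports. "The series", "measured", "known", "first", "only" and "open" are said of these compounds alone.

Measured so far:
compound 1, `CN1CCN(CCCS(=O)(=O)c2ccc3nc(NC(=O)NC(=O)c4cc(C5CC5)ccc4Cl)sc3c2)CC1`: 1400 nM
compound 2, `CCOc1ccc(Cl)c(C(=O)NC(=O)Nc2nc3ccc(S(=O)(=O)CCCN4CCN(C)CC4)cc3s2)c1`: 4200 nM

In an ADME assay on the whole organism (strain Han-Wistar) for pharmacokinetics, with Rattus norvegicus as the target, read by LC-MS, at a dose of 2 mg/kg by the oral route (on this read-out lower numbers stand for lower exposure and higher numbers for higher exposure at the dose given), compound 1 gives 1400 nM, while compound 2 gives 4200 nM. Compound 2 thus holds the higher of the two numbers. Within the data shown here, the single measured step in this assay is a 3.0-fold higher number from compound 1 to compound 2 (0.48 log units; beyond the scatter), a change at the same aromatic carbon that compound 3 now alters again.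

Compound 3, `Cc1ccn(-c2ccc(Cl)c(C(=O)NC(=O)Nc3nc4ccc(S(=O)(=O)CCCN5CCN(C)CC5)cc4s3)c2)n1`, carries 3-methyl-1H-pyrazol-1-yl in place of ethoxy on an aromatic carbon. Among the measured compounds shown here, no measured step swaps these two groups, so the only guide is a 3.0-fold higher number from compound 1 to compound 2 (0.48 log units; beyond the scatter), which shows that a change at this position can move exposure modestly but not strongly. A modest step is therefore expected for a 1.7-fold lower number from compound 2 to compound 3 (0.23 log units; within the scatter), more likely downward than upward, with a real chance of no change beyond the scatter. Compound 3 is estimated at 2500 nM, with a range from 800 nM to 8000 nM.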

Compound 3, maximal plasma concentration: 410 nM
Estimate against measurement, compound 3: 6.1-fold (0.79 log units) above, and the stated range ends above it.
By their numbers in this assay, from the lowest: compound 3; then compound 1; then compound 2.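

In this assay, the aromatic carbon para to a chloro group proves able to move exposure much further than a 3.0-fold higher number from compound 1 to compound 2 (0.48 log units; beyond the scatter) suggested, since the new change gives a 10-fold lower number from compound 2 to compound 3 (1.01 log units; beyond the scatter), a large step. The 3-methyl-1H-pyrazol-1-yl group also falls short of cyclopropyl, with a 3.4-fold lower number from compound 1 to compound 3 (0.53 log units; beyond the scatter), which leaves compound 3 lowest of the three, with both of its steps beyond the scatter. Nothing available on these compounds accounts for the drop.

On these data alone, what stays open is whether the fall goes with the five-membered aromatic ring itself, with its methyl group, or with the larger group of 6 heavy atoms in place of 3. An unsubstituted 1H-pyrazol-1-yl group or a longer alkoxy chain such as propoxy at this carbon would help separate these readings.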